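Sulfonamide glycinamides: heteroaryl swap on the sulfonamide nitrogen

The source may hold more compounds than are shown below. What is called first, only, known or untested is meant among the compounds shown, and "the series" means these compounds.

Measured so far in an assay on CHO cells for displacement of a labelled ligand from prostaglandin E2 receptor EP1 subtype (Homo sapiens); on this read-out lower numbers stand for stronger inhibition and higher numbers for weaker inhibition:
- compound 1 `Cc1ccc(S(=O)(=O)N(CC(=O)NCc2ccc(Cl)cc2)c2ccccn2)cc1` gives < 1000 nM
- compound 2 `Cc1ccc(S(=O)(=O)N(CC(=O)NCc2ccc(Cl)cc2)c2ccc(C)nc2)cc1` gives < 1000 nM

Both values are limits of this assay, not numbers. Compound 2 sits at a limit in this assay, as summarised by the limit of < 1000 nM in this assay, at which 2 of the 2 values shown sit. Going by the values given here, the single measured step, a step that the two limits leave unreadable from compound 1 to compound 2, is therefore unreadable in size and direction.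

Compound 3 `Cc1ccc(S(=O)(=O)N(CC(=O)NCc2ccc(Cl)cc2)c2ccnn2C)cc1` differs from compound 2 in one place: 1-methyl-1H-pyrazol-5-yl in place of 6-methylpyridin-3-yl on a sulfonamide nitrogen. Among the compounds with values here, no measured step bears on this exchange, since the only step, from compound 1 to compound 2, cannot be read. Nothing in the data shows that a change on the sulfonamide nitrogen moves this assay beyond the scatter, so no step beyond the scatter is expected from compound 2 to compound 3, and the most likely outcome is again a value at the limit.

Compound 3 is estimated at 300 nM, with a range of 30 nM to 3000 nM in this assay; the expected step is a step that the limit leaves unreadable from compound 2 to compound 3.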

Compound 3, inhibition constant: 398 nM
Estimate against measurement, compound 3: 1.3-fold (0.12 log units) below; the range from low to high includes it.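

No step from compound 1 or compound 2 to compound 3 can be read in this assay, because the values of compound 1 and compound 2 are limits: the limit of < 1000 nM in this assay, at which 2 of the 3 values shown sit.

Going by these compounds, whether exchanging the heteroaryl group on the sulfonamide nitrogen moves this read-out at all remains open.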